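Swapping a Sulfonamide for Dichlorines on the Benzyl Arm

A few compounds are considered here, and "the series" means these few. Any claim that something is new, unique, unknown or untested is made for them only; others in the source may bear on it.

Four compounds sharing one core are considered here. Compound 1 `COc1cc2c(=O)c(C(=O)c3ccc(C)cc3)cn(Cc3ccc(N)cc3)c2cc1OC` carries an aminophenyl group on the benzyl arm, and in an ADME assay on Huh-7 cells (Homo sapiens) for cytotoxicity (a higher number here means a weaker inhibitor of growth, a lower number a stronger inhibitor of growth), compound 1 is recorded as "not active" (no number reported) without a number. Compound 2 `COc1cc2c(=O)c(C(=O)c3ccc(C)cc3)cn(Cc3ccc(S(N)(=O)=O)cc3)c2cc1OC` carries a sulfamoylphenyl group in the same position. In this assay compound 2 reaches only the limit of > 25000 nM, so no single number stands for it. Compound 3 `COc1cc2c(=O)c(C(=O)OCc3cccc(C)c3)cn(Cc3ccc(C(F)(F)F)cc3F)c2cc1OC` differs in several places at once, and in this assay compound 3 gives 7300 nM. Thus compound 2 sits at the top of what the numbers show, at the limit of > 25000 nM in this assay, at which 1 of the 3 values shown sits.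

Compound 4 `COc1cc2c(=O)c(C(=O)c3ccc(C)cc3)cn(Cc3ccc(Cl)c(Cl)c3)c2cc1OC` is the unmeasured compound. Among the compounds with values here, its only change from compound 2 is 3,4-dichlorophenyl in place of 4-sulfamoylphenyl on a saturated chain carbon bound to an aromatic nitrogen. Within the data shown here, no measured pair that differs in one place is available to size this change. The sulfonamide of compound 2 leaves and two chlorine atoms enter, and the expectation is a step in this assay toward a lower number, meaning stronger inhibition of growth, larger than the scatter. Compound 4 is therefore expected to give about 10000 nM, with a range from 3000 nM to 25000 nM, which is an estimated step of an at least 2.5-fold lower number from compound 2 to compound 4 (0.39 log units; beyond the scatter).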

Compound 4, concentration for 50% growth inhibition: "not active" (no number reported)
Compound 4: no number reported; the estimate stays without a comparison.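

In this assay, within the data shown here, compound 4 is recorded as "not active" (no number reported), so no step from compound 2 to compound 4 can be read. Compound 2 itself has only a limit and not a number: the limit of > 25000 nM in this assay, at which 1 of the 4 values shown sits. The compounds shown leave open how far, if at all, replacing 4-sulfamoylbenzyl with 3,4-dichlorobenzyl shifts growth inhibition.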